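A few compounds are considered here, and "the series" means these few. Any claim that something is new, unique, unknown or untested is made for them only; others in the source may bear on it.

In a functional assay on A549 cells (Homo sapiens) for antiproliferative activity, read by MTT assay, with a stated time of 48 h (a higher number here means a weaker inhibitor, a lower number a stronger inhibitor), compound 1 `CCCCC1(O)C(=O)Nc2ccc(Nc3ccc(C)cc3)cc21` gives 7500 nM while compound 2 `CCCCCC1(O)C(=O)Nc2ccc(Nc3ccc(C)cc3)cc21` gives 8100 nM and compound 3 `Cc1ccc(Nc2ccc3c(c2)C(O)(Cc2ccccc2)C(=O)N3)cc1` gives 4100 nM as its reading. These compounds differ only in the chain on a saturated ring carbon, and the steps of a 1.1-fold higher number from compound 1 to compound 2 (0.03 log units; within the scatter) and a 1.8-fold lower number from compound 1 to compound 3 (0.26 log units; within the scatter) and a 2.0-fold lower number from compound 2 to compound 3 (0.30 log units; within the scatter) all lie within the scatter. Compound 2 therefore stands level with both of the others on these numbers.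

Compound 4 `CCCCCC1(O)C(=O)Nc2ccc(Nc3ccc(F)cc3)cc21` keeps the chain of compound 2 and changes a different place fluoro in place of methyl on an aromatic carbon with fluoro in place of methyl on an aromatic carbon, so that 4-methylphenyl becomes 4-fluorophenyl. For the measured compounds named here, no measured step touches this aromatic ring, so those three steps bear on it only indirectly. No step beyond the scatter is expected in this assay and no direction is favoured, though nothing measured here tests this change. The expected step is a 1.2-fold lower number from compound 2 to compound 4 (0.06 log units; within the scatter) and it is only an estimate. Compound 4 is estimated at 7000 nM with 3200 nM to 15000 nM as the expected range.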

Compound 4, half-maximal inhibitory concentration: 5900 nM
Compound 4: the middle estimate sits 1.2-fold (0.07 log units) above what was measured; measured number inside the range.
By their numbers in this assay, from the lowest: compounds 3, 4, 1 and 2 (each within the scatter of the next).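

Compound 4 is the only compound shown that alters the aromatic ring carrying the methyl group, whereas the others differ only in the chain on the saturated ring carbon. In this assay, replacing 4-methylphenyl with 4-fluorophenyl gives a 1.4-fold lower number from compound 2 to compound 4 (0.14 log units; within the scatter), so fluoro and methyl read level on this aromatic carbon, para to a large group, and this ring position can take either group with the chain of compound 2 in place. No supporting measurement is available to explain this reading.

The compounds shown leave open how a chloro, methoxy or carboxylic acid group would read at this same place. They also leave open whether fluoro and methyl would still read level alongside the chain of compound 3.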